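The source may report more compounds than this note shows. Statements on the series, on what has been measured and on what is new or still open speak of the compounds shown alone.

Of the compounds shown here, three built on one shared core have been measured in a functional assay for inhibition, with Homo sapiens as the target; a higher number here means a weaker inhibitor, a lower number a stronger inhibitor. Compound 1 `Cc1cc(C)cc(Nc2nccc(-c3ccccn3)n2)c1` gives 100 nM, compound 2 `Fc1cccc(Nc2nccc(-c3ccccn3)n2)c1` gives 1000 nM, and compound 3 `COc1ccc(Nc2nccc(-c3cccs3)n2)cc1` gives 3900 nM. Compound 2 therefore holds the second highest of the three numbers: compound 3 sits above it, beyond the usual scatter, while compound 1 sits well below it, also beyond the scatter. Compound 4 `CC(=O)Nc1cccc(Nc2nccc(-c3ccccn3)n2)c1` has not yet been measured. It differs from compound 2 by a single change: acetamido in place of fluoro on an aromatic carbon. Among the measured compounds shown here, no measured pair here shows this particular change, so its effect cannot be read from the data. Compound 4 is expected to give 1500 nM, with a likely range from 400 nM to 6000 nM. The step of a 1.5-fold higher number from compound 2 to compound 4 (0.18 log units; within the scatter) is expected to be small, at most a modest weakening, and may well fall within the scatter.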

Compound 4, half-maximal inhibitory concentration: 300 nM
For compound 4 the middle estimate is 5.0-fold (0.70 log units) above the measured one, and the stated range ends above it.
By their numbers in this assay, from the lowest: compound 1; then compound 4; then compound 2; then compound 3.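

In this assay, replacing fluoro with acetamido gives a 3.3-fold lower number from compound 2 to compound 4 (0.52 log units; beyond the scatter), so this position, meta to a large group, accepts a larger group and the inhibitor becomes stronger rather than weaker. Unlike fluoro, acetamido carries a hydrogen-bond donor and a hydrogen-bond acceptor, but this single pair cannot show whether either feature or the larger size matters. No available evidence explains the gain. Going by these compounds, an amine, a carboxylic acid or a longer chain at this position could behave differently, so it remains open how far the gain extends beyond acetamido.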